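Replacing pyridin-2-yl on a nitrogen on an aromatic ring

The source may hold more compounds than are shown below. What is called first, only, known or untested is meant among the compounds shown, and "the series" means these compounds.

Values in a functional assay on SF-268 cells (Homo sapiens) for cytotoxicity, read by MTT assay, with a stated time of 3 days; on this read-out lower numbers stand for stronger inhibition and higher numbers for weaker inhibition:
- compound 1 `N#Cc1c(O)nc(SCc2nc3ccccc3[nH]2)nc1-c1ccccc1` gives 3.2 nM
- compound 2 `CNc1nc(SCc2nc3ccccc3[nH]2)nc(-c2ccccc2)c1C#N` gives 3.2 nM
- compound 3 `N#Cc1c(Nc2ccccn2)nc(SCc2nc3ccccc3[nH]2)nc1-c1ccccc1` gives 6.75 nM

Compound 3 carries the highest number of the three, with both other compounds modestly lower. Its relative, compound 4 `N#Cc1c(NNC(N)=S)nc(SCc2nc3ccccc3[nH]2)nc1-c1ccccc1`, has not yet been measured. The structural change is a group of 4 heavy atoms (1 carbon, 2 nitrogen, 1 sulfur; no ring) in place of a group of 6 heavy atoms (5 carbon, 1 nitrogen; one six-membered aromatic ring with 1 hetero atom), on a nitrogen on an aromatic ring. For the measured compounds named here, no measured compound carries a group like the one entering, so the evidence is only indirect.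

Going by the values given here, three measured steps bear on this change. The closest is the replacement of methyl by pyridin-2-yl on that same nitrogen, which gave a 2.1-fold higher number from compound 2 to compound 3 (0.32 log units; beyond the scatter). Replacing hydroxy by (pyridin-2-yl)amino gave a 2.1-fold higher number from compound 1 to compound 3 (0.32 log units; beyond the scatter), while replacing hydroxy by methylamino gave no change at the digits printed from compound 1 to compound 2 (within the scatter). Among these three compounds, then, changes at this place moved the number only modestly, and the largest steps both lead to compound 3.

No step beyond the scatter is therefore expected in this assay, with a slight lean towards a lower number, as compound 2, which lacks pyridin-2-yl, stands at 3.2 nM. The step expected is a 1.4-fold lower number from compound 3 to compound 4 (0.13 log units; within the scatter). Compound 4 is estimated at 5 nM, within an expected range of 2 nM to 14 nM.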

Compound 4, half-maximal inhibitory concentration: 3.37 nM
For compound 4 the middle estimate is 1.5-fold (0.17 log units) above the measured one; measured number inside the range.
By their numbers in this assay, from the lowest: compounds 1, 2, 4 and 3 (each within the scatter of the next, the first and the last beyond it).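

In this assay, a group of 4 heavy atoms with no ring, carrying sulfur and two nitrogens, sits on a nitrogen on an aromatic ring in place of pyridin-2-yl, and the result is a 2.0-fold lower number from compound 3 to compound 4 (0.30 log units; within the scatter). The new compound also stays close to the two smaller substituents, with a 1.1-fold higher number from compound 2 to compound 4 (0.02 log units; within the scatter) and a 1.1-fold higher number from compound 1 to compound 4 (0.02 log units; within the scatter), so this place accepts an open-chain group of this size without a step beyond the scatter from any of the three earlier compounds, and compound 3 is no longer set apart from every other compound shown, since it lies beyond the scatter only from compound 1 and compound 2. No measurement at hand gives a reason for this tolerance.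

Going by these compounds, whether the same flat picture would hold with a carboxylic acid, a morpholine or a longer alkyl chain at this place remains open, and so does whether an unsubstituted amine would fit it. The compounds shown also leave open how far this tolerance depends on the rest of the shared core, which stays unchanged throughout.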